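The source may hold more compounds than are shown below. What is called first, only, known or untested is meant among the compounds shown, and "the series" means these compounds.

Compound 3, `C/C=C/C(=O)Nc1ccc(Cn2nc(-c3ccc(Oc4ccccc4)cc3)cc2C(=O)O)cc1`, carries a carboxy group on the shared core and a crotonamide on the side chain. In a functional assay on Z-138 cells (Homo sapiens) for inhibition, read by luminescence and CellTiter-Glo, with a stated time of 72 h (on this read-out lower numbers stand for stronger inhibition and higher numbers for weaker inhibition), compound 3 reaches only the assay limit, > 60000 nM, and no number is known for it. It therefore sits at the limit of > 60000 nM in this assay, at which 1 of the 3 values shown sits, the weakest position the read-out can report. Within the data shown here, for comparison, compound 1, `C=CC(=O)Nc1ccc(Cn2nc(-c3ccc(Oc4ccccc4)cc3)cc2CO)cc1`, gives 6800 nM, and compound 2, `O=C(CCl)Nc1ccc(Cn2nc(-c3ccc(Oc4ccccc4)cc3)cc2CO)cc1`, gives 400 nM; the single measured step, a 17-fold lower number from compound 1 to compound 2 (1.23 log units; beyond the scatter), concerns the carbonyl carbon and not the group on the core, so it does not bear directly on the change studied here.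

Compound 4, `C/C=C/C(=O)Nc1ccc(Cn2nc(-c3ccc(Oc4ccccc4)cc3)cc2CO)cc1`, differs from compound 3 in one place: hydroxymethyl in place of carboxy on an aromatic carbon. Among the measured compounds shown here, no measured pair shows what this exchange does. Compound 3 stands at the assay limit. The expectation rests on that and on compound 1, the hydroxymethyl analogue with a closely related side chain, giving 6800 nM. Compound 4 is therefore expected to move back into the measurable range, as an at least 2.4-fold lower number from compound 3 to compound 4 (0.38 log units; beyond the scatter), with an estimated value of 25000 nM and a plausible range from 7000 nM to 100000 nM.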

Compound 4, half-maximal inhibitory concentration: 54500 nM
For compound 4 the middle estimate is 2.2-fold (0.34 log units) below the measured one; the range from low to high includes it.
By their numbers in this assay, from the lowest: compound 2; then compound 1; then compound 4. At a limit, above all of these: compound 3.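

Compound 3 remains a limit of the read-out and not a number: the limit of > 60000 nM in this assay, at which 1 of the 4 values shown sits.

In this assay, the exchange of carboxy for hydroxymethyl on this aromatic carbon therefore reads only as an at least 1.1-fold lower number from compound 3 to compound 4 (0.04 log units; that floor lies within the scatter), so the pair does not establish a real gain from this change. The clearer news lies on the carbonyl carbon: with hydroxymethyl held on the core, prop-1-en-1-yl in place of vinyl gives an 8.0-fold higher number from compound 1 to compound 4 (0.90 log units; beyond the scatter), and prop-1-en-1-yl in place of chloromethyl gives a 140-fold higher number from compound 2 to compound 4 (2.13 log units; beyond the scatter).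

The compounds shown leave open how an amine or a methyl ester at this place on the core would compare with hydroxymethyl. They also leave open whether a longer chain on the carbonyl carbon would raise the number further, and whether carboxy would stay at the limit alongside a chloromethyl group there.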